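The source may hold more compounds than are shown below. What is called first, only, known or untested is meant among the compounds shown, and "the series" means these compounds.

Measured in a functional assay on MDA-MB-468 cells (Homo sapiens) for antiproliferative activity, read by MTT assay, with a stated time of 72 h; a lower number here means a stronger inhibitor, a higher number a weaker inhibitor:
- compound 1 `CCCn1ccnc1-c1cc(OC)c(OC)c(OC)c1`: > 100000 nM, a limit
- compound 2 `COc1cc(-c2nccn2Cc2ccccc2)cc(OC)c1OC`: > 100000 nM, a limit
- compound 3 `COc1ccc(-n2ccnc2-c2cc(OC)c(OC)c(OC)c2)cc1[N+](=O)[O-]`: 100 nM

Compound 3 holds the only number among these, and the other two values are limits. The change to compound 4 `COc1ccc(-n2ccnc2-c2cc(OC)c(OC)c(OC)c2)cc1` is hydrogen in place of nitro on an aromatic carbon, with hydrogen in place of nitro on an aromatic carbon. Going by the values given here, the only measured step, a step that the two limits leave unreadable from compound 1 to compound 2, lies at another place and gives no readable size, so no measured step sizes this change. In this assay a modest weakening is tentatively expected, a 3.0-fold higher number from compound 3 to compound 4 (0.48 log units; beyond the scatter), although a step within the scatter remains possible. The estimated value for compound 4 is 300 nM, with an expected range from 30 nM to 3000 nM.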

Compound 4, half-maximal inhibitory concentration: 500 nM
Compound 4: the middle estimate sits 1.7-fold (0.22 log units) below what was measured; the range from low to high includes it.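

In this assay, the nitro group on the aromatic carbon ortho to a methoxy group is not essential for a measurable value, though its loss gives a 5.0-fold higher number from compound 3 to compound 4 (0.70 log units; beyond the scatter). Placing 4-methoxyphenyl on the aromatic nitrogen gives much larger steps, an at least 200-fold lower number from compound 2 to compound 4 (2.30 log units; beyond the scatter) for benzyl replaced and an at least 200-fold lower number from compound 1 to compound 4 (2.30 log units; beyond the scatter) for propyl replaced. Both sizes are bounded by a limit rather than a number: the limit of > 100000 nM in this assay, at which 2 of the 4 values shown sit.

Going by these compounds, whether an amine or fluorine on that aromatic carbon would match nitro remains open. So does whether a hydroxyl could replace the methoxy group of the 4-methoxyphenyl substituent.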